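The source may hold more compounds than are shown below. What is called first, only, known or untested is meant among the compounds shown, and "the series" means these compounds.

Working notes on the series. The shared core carries a carboxylic acid, an amide and an ether-linked fused system; the measured compounds differ only in where one fluoro sits on that system. In a functional assay on ileum (Cavia porcellus) for antagonist activity at cysteinyl leukotriene receptor (Homo sapiens) (on this read-out lower numbers stand for stronger inhibition and higher numbers for weaker inhibition), compound 1 `CCC(CC)(CC(=O)Nc1cccc(OCc2ccc3c(F)cccc3n2)c1)C(=O)O` gives 0.3 nM. Compound 2 `CCC(CC)(CC(=O)Nc1cccc(OCc2ccc3cc(F)ccc3n2)c1)C(=O)O` gives 2 nM in this assay. Compound 3 `CCC(CC)(CC(=O)Nc1cccc(OCc2ccc3cccc(F)c3n2)c1)C(=O)O` gives 6 nM in this assay. Compound 2 therefore stands second highest of the three numbers: its nearest neighbour is compound 3, whose number is higher by a margin beyond the scatter, and compound 1 lies furthest off, with a lower number, also beyond the scatter.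

Compound 4 `CCC(CC)(CC(=O)Nc1cccc(OCc2ccc3cc(F)c(F)cc3n2)c1)C(=O)O` is not yet measured. Against compound 2 the change is fluoro in place of hydrogen on an aromatic carbon. Going by the values given here, no step between measured compounds adds a second fluoro on that ring, so there is no measured guide for the size of this step. A step of a 1.5-fold higher number from compound 2 to compound 4 (0.18 log units; within the scatter) in this assay is expected, not clearly beyond the scatter, leaning if anywhere toward a weaker number. For compound 4 the estimate in this assay is 3 nM, with a range from 0.8 nM to 12 nM.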

Compound 4, half-maximal inhibitory concentration: 0.5 nM
Compound 4: the middle estimate sits 6.0-fold (0.78 log units) above what was measured, outside the stated range (below it).
By their numbers in this assay, from the lowest: compounds 1 and 4 (each within the scatter of the next); then compound 2; then compound 3.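

In this assay, the step of a 4.0-fold lower number from compound 2 to compound 4 (0.60 log units; beyond the scatter) shows that this ring carbon, ortho to a fluoro group, accepts fluoro in place of hydrogen, with a lower number beyond the scatter. Going by these compounds alone, the earlier compounds varied only where a single fluoro sat, so this step is the first reading of a second fluoro on the same ring, and here the added fluoro strengthens inhibition rather than leaving it unchanged. Nothing measured here bears on why the number falls.

On these data alone, whether this step is particular to fluoro stays open, since a chloro, a methyl or a methoxy at the same carbon would test that. Also open, as far as these compounds go, is whether a second fluoro gives a similar step when the first sits where it does in compound 1 or compound 3.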